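This account rests on a few compounds, and the source may have more. Where it says the series, first, only, none or still open, it means among the compounds named here.

Three compounds share one core. Compound 1 `COc1cc2c(Oc3ccc(NC(=O)N/N=C/c4ccc(N(C)C)cc4)cc3F)ccnc2cc1OCCCN1CCCCC1` carries a dimethylamino-substituted aryl hydrazone; in a functional assay on A549 cells (Homo sapiens) for cytotoxicity, read by MTT assay, with a stated time of 72 h (on this read-out higher numbers stand for weaker inhibition and lower numbers for stronger inhibition), the entry for compound 1 reads "not determined" (no result reported), so no number is available for it. Compound 2 `COc1cc2c(Oc3ccc(NC(=O)N/N=C/c4cccs4)cc3F)ccnc2cc1OCCCN1CCCCC1` is therefore the only member with a measured result: in this assay compound 2 gives 790 nM, and it stands alone among the numbers shown, with nothing to rank it against.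

Compound 3 `COc1cc2c(Oc3ccc(/C=N/NC(=O)Nc4ccccc4)cc3F)ccnc2cc1OCCCN1CCCCC1` has not been tested. It differs from compound 2 in one change: a group of 12 heavy atoms (8 carbon, 3 nitrogen, 1 oxygen; one six-membered aromatic ring of carbon only) in place of a group of 11 heavy atoms (6 carbon, 3 nitrogen, 1 oxygen, 1 sulfur; one five-membered aromatic ring with 1 hetero atom), on an aromatic carbon. In words, a group of 12 heavy atoms (8 carbon, 3 nitrogen, 1 oxygen; one six-membered aromatic ring of carbon only) takes the place of a group of 11 heavy atoms (6 carbon, 3 nitrogen, 1 oxygen, 1 sulfur; one five-membered aromatic ring with 1 hetero atom), on an aromatic carbon.

For the measured compounds named here, no pair of measured compounds shows what such a change does here. With only the value of compound 2 as an anchor, a modest step toward weaker inhibition, not far beyond the scatter, is expected for a 1.9-fold higher number from compound 2 to compound 3 (0.28 log units; within the scatter). Compound 3 is accordingly estimated at 1500 nM, within a range from 400 nM to 6000 nM.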

Compound 3, half-maximal inhibitory concentration: 280 nM
The estimate for compound 3 lay 5.4-fold (0.73 log units) above the measured number; the measured number lies below the stated range.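

In this assay, for the compounds shown here, the change at the aromatic carbon para to a large group brings a 2.8-fold lower number from compound 2 to compound 3 (0.45 log units; beyond the scatter), the first step that can be read at this position. It shows that the group with the six-membered aromatic ring of carbon only gives stronger inhibition here than the group with the five-membered aromatic ring with 1 hetero atom, a comparison that compound 1, with no reported number, could not supply. Nothing available explains this step, and the result by itself gives no reason for it.

The two groups differ in more than their rings, since the chain runs in opposite directions: the carbon-nitrogen double bond stands on the aromatic carbon in compound 3, while a nitrogen bearing the amide hydrogen stands there in compound 2, and the compounds shown do not separate the share of the ring from that of the chain's direction. On these data alone, it also remains open how a chloro group or a carboxylic acid on the six-membered ring of compound 3 would affect inhibition in this assay.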